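The source may report more compounds than this note shows. Statements on the series, on what has been measured and on what is new or still open speak of the compounds shown alone.

Measured so far:
compound 1 `COCc1cc(OC)c(-c2cccc3c(N(CC4CCOCC4)CC4CC4)c(C)nn23)c(OC)c1`, 120 nM
compound 2 `CCCN(CC1CCOCC1)c1c(CC)nn2c(-c3c(OC)cc(COC)cc3OC)cccc12`, 90 nM
compound 3 `CCc1nn2c(-c3c(C)cc(C)cc3OC)cccc2c1N(CC1CC1)CC1CCCO1`, 34 nM

All three numbers come from an assay on HEK293 cells for displacement of a labelled ligand from corticotropin-releasing factor receptor 1 (Homo sapiens), read by scintillation counting, with a stated time of 2 h; on this read-out lower numbers stand for stronger inhibition and higher numbers for weaker inhibition. In this assay compound 2 gives 90 nM and stands second highest of the three. Compound 1 gives 120 nM, which lies within the scatter of the value of compound 2, so no order between these two can be read. For the measured compounds named here, compound 3 gives 34 nM, a lower number beyond the scatter; compound 3 differs from compound 2 in more than one place, so the two values show only that compound 3 inhibits more strongly than compound 2, and say nothing about any single change.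

Compound 4 `CCc1nn2c(-c3c(OC)cc(COC)cc3OC)cccc2c1N(CC1CCOCC1)CC1CC1` has not yet been measured in this assay. It differs from compound 2 in one place: cyclopropyl in place of ethyl on a saturated chain carbon bound to a nitrogen on an aromatic ring. Going by the values given here, no step between measured compounds isolates this change. Compound 3 also carries the cyclopropylmethyl group on its amine nitrogen and gives the lowest number, but its other differences from compound 2 leave that comparison open.

The expectation is a small step toward a lower number, of size a 1.5-fold lower number from compound 2 to compound 4 (0.18 log units; within the scatter), which may not exceed the scatter. Compound 4 is estimated at 60 nM in this assay, within a range of 25 nM to 150 nM.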

Compound 4, half-maximal inhibitory concentration: 50 nM
Beside the measured number, compound 4's estimate is 1.2-fold (0.08 log units) above it; the range from low to high includes it.
By their numbers in this assay, from the lowest: compounds 3, 4, 2 and 1 (each within the scatter of the next, the first and the last beyond it).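

In this assay, the effect of cyclopropyl in place of ethyl on a saturated chain carbon bound to a nitrogen on an aromatic ring can now be read in isolation, and a 1.8-fold lower number from compound 2 to compound 4 (0.26 log units; within the scatter) gives no readable order for this change, which reads as propyl to cyclopropylmethyl when cut one bond further out. For the compounds shown here, compound 4 also isolates a second place: methyl in place of hydrogen on a saturated chain carbon bound to an aromatic carbon gives a 2.4-fold lower number from compound 1 to compound 4 (0.38 log units; beyond the scatter) and is a modest step, the only single-place step so far that clears the scatter. No measurement at hand bears on the reason for either step.

At the amine nitrogen, the compounds shown leave open whether a cyclobutyl group or a longer chain such as butyl would give a step beyond the scatter, where the present change does not. From the compounds shown here alone, at the saturated chain carbon bound to an aromatic carbon, a hydroxyl group or a fluorine atom remains unexplored, so it is open whether the modest step there depends on a carbon substituent.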